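The compounds below may be only part of what the source reports. "The series", "measured", "known", "first", "only" and "open" are said of these compounds alone.

Measured compounds in a functional assay on A549 cells (Homo sapiens) for inhibition, read by MTT assay, with a stated time of 72 h; on this read-out lower numbers stand for stronger inhibition and higher numbers for weaker inhibition
- compound 1 `C=C1CC[C@H]2[C@](C)(CO)CCC[C@]2(C)[C@H]1C[C@@]12O[C@@H]1[C@@H](O)C(CO)=CC2=O` gives 41500 nM
- compound 2 `C=C1CC[C@H]2[C@](C)(COC(C)=O)CCC[C@]2(C)[C@H]1C[C@]12O[C@H]1[C@H](O)C(CO)=CC2=O` gives 29400 nM

Compound 2 and compound 1 lie within the scatter of each other, so these two numbers set no order between them. Compound 3 `C=C1CC[C@H]2[C@](C)(COC(C)=O)CCC[C@]2(C)[C@H]1C[C@@]12O[C@@H]1[C@@H](O)C(CO)=CC2=O` has the same atoms and bonds as compound 2 and differs only in configuration as drawn, at saturated ring carbons: the two compounds have the same atoms and bonds and differ only in configuration as drawn: 3 of 7 stereo elements differ; a stereocentre at a saturated ring carbon is drawn S in compound 2 and R in compound 3; a stereocentre at a saturated ring carbon is drawn S in compound 2 and R in compound 3; a stereocentre at a saturated ring carbon is drawn R in compound 2 and S in compound 3. Nothing leaves and nothing enters. Among the compounds with values here, no step between measured compounds shows what a change of configuration does in this assay, so no direction is favoured and no step beyond the scatter is expected. The starting point for the expectation is compound 2 at 29400 nM as measured. The estimated change is a 1.1-fold lower number from compound 2 to compound 3 (0.02 log units; within the scatter) and the uncertainty on it is wide. Compound 3 is expected at 28000 nM with an estimated range from 11000 nM to 70000 nM in this read-out.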

Compound 3, half-maximal inhibitory concentration: 18000 nM
Estimate against measurement, compound 3: 1.6-fold (0.19 log units) above; the measured number falls inside the stated range.
By their numbers in this assay, from the lowest: compounds 3, 2 and 1 (each within the scatter of the next, the first and the last beyond it).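

In this assay, inverting three stereocentres at saturated ring carbons gives a 1.6-fold lower number from compound 2 to compound 3 (0.21 log units; within the scatter), so this pair sets no order, and drawn configuration has no shown effect on this read-out. This reading rests on one structural fact: the fact that compounds 2 and 3 differ only in the configuration as drawn

Acetyl in place of hydrogen on an oxygen on a saturated carbon gives a 2.3-fold lower number from compound 1 to compound 3 (0.36 log units; beyond the scatter), the only step in the series beyond the scatter, and a modest one resting on a single pair.

On these data alone, whether a longer acyl chain, an amine or a carboxylic acid in place of the acetyl would carry the number further remains open. Also open, as far as these compounds go, is what each of the three stereocentres does when inverted alone, since the pair shows them only changing together.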